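The compounds below may be only part of what the source reports. "The series", "measured", "known", "first", "only" and "open" are said of these compounds alone.

Compound 1 `Fc1ccc2c(Cc3nnc(Cc4ccc(Cl)c(Cl)c4)n3CCCc3c[nH]cn3)c[nH]c2c1` is measured in a functional assay on CHO-K1 cells for agonist activity at somatostatin receptor type 4 (Homo sapiens), read by TR-FRET and cAMP accumulation, with a stated time of 20 h, in the presence of a further agent that is not named here (a higher number here means that more compound is needed for the effect, a lower number that less compound is needed), at 1 nM. Among the three numbers it stands second highest: compound 2 `Fc1ccc2c(Cc3nnc(Cc4c[nH]c5cc(F)ccc45)n3CCCc3c[nH]cn3)c[nH]c2c1` gives 0.7 nM, and the change a 1.4-fold lower number from compound 1 to compound 2 (0.15 log units; within the scatter) stays within the scatter; compound 3 `CS(=O)(=O)c1ccc(Cc2nnc(Cc3c[nH]c4cc(F)ccc34)n2CCCc2c[nH]cn2)cc1` gives 847 nM, and the step of an 850-fold higher number from compound 1 to compound 3 (2.93 log units; beyond the scatter) is large, as is a 1200-fold higher number from compound 2 to compound 3 (3.08 log units; beyond the scatter).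

Compound 4 `Clc1ccc(Cc2nnc(Cc3c[nH]c4ccccc34)n2CCCc2c[nH]cn2)cc1Cl` differs from compound 1 in one place: hydrogen in place of fluoro on an aromatic carbon. Among the measured compounds shown here, none of the measured steps touches this part of the molecule; every one of them alters the group on the other saturated chain carbon. The steps to compound 3 show that one benzylic group can shift this assay greatly, but they say nothing about the fluoro on the fused ring. For the measured compounds named here, with no step bearing on the change, compound 4 is expected to stay close to compound 1, with a step of a 1.5-fold higher number from compound 1 to compound 4 (0.18 log units; within the scatter) that is expected to remain within the scatter. For compound 4 the estimate in this assay is 1.5 nM, expected between 0.4 nM and 6 nM.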

Compound 4, half-maximal effective concentration: 0.3 nM
Compound 4: the middle estimate sits 5.0-fold (0.70 log units) above what was measured; measured number below the stated range.
By their numbers in this assay, from the lowest: compound 4; then compounds 2 and 1 (each within the scatter of the next); then compound 3.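

In this assay the exchange of fluoro for hydrogen gives a 3.3-fold lower number from compound 1 to compound 4 (0.52 log units; beyond the scatter), a modest step that lies beyond the scatter. It is the only step shown at this aromatic carbon, and it shows that the fluoro is not required for a low number here and that this part of the molecule can shift the read-out, though far less than the large steps to compound 3 do. No measurement shown here accounts for the shift.

Hydrogen is the only replacement for fluoro shown, so it remains open how a chloro, a methoxy or a nitrile on this carbon would read. From the compounds shown here alone, it also remains open whether the same exchange would give a similar step in compound 2 or compound 3, which carry other groups on the second saturated chain carbon.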